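A trifluoromethyl swap at the limit of a cytotoxicity test

The source may hold more compounds than are shown below. What is called first, only, known or untested is meant among the compounds shown, and "the series" means these compounds.

Compound 1 (`CC(C)N(Cc1cccc(OCCCCCC(=O)O)c1)C(=O)c1ccc(-c2ccoc2)cc1`), compound 2 (`CCOc1cccc(-c2ccc(C(=O)N(Cc3cccc(OCCCCCC(=O)O)c3)C(C)C)cc2)c1`) and compound 3 (`COc1cc(F)cc(-c2ccc(C(=O)N(Cc3cccc(OCCCCCC(=O)O)c3)C(C)C)cc2)c1`) share one core and differ in a single place. In an ADME assay on HepG2 cells (Homo sapiens) for cytotoxicity, read by CellTiter-Glo and resazurin assay, with a stated time of 72 h (on this read-out lower numbers stand for an effect already at smaller amounts and higher numbers for an effect only at larger amounts of compound), compound 1 gives > 26000 nM as a limit and not a number. Compound 2 gives > 20800 nM as a limit too. Compound 3 gives > 26000 nM as a limit as well. Compound 3 therefore stands only at a limit (the limit of > 26000 nM in this assay, at which 2 of the 3 values shown sit) and has no exact number.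

Compound 4 (`CC(C)N(Cc1cccc(OCCCCCC(=O)O)c1)C(=O)c1ccc(-c2cccc(C(F)(F)F)c2)cc1`) carries 3-(trifluoromethyl)phenyl in place of 3-fluoro-5-methoxyphenyl on an aromatic carbon. The measured steps that bear on this change are swaps at the same place (a step that the two limits leave unreadable from compound 1 to compound 2; a step that the two limits leave unreadable from compound 1 to compound 3; a step that the two limits leave unreadable from compound 2 to compound 3), and none has a readable size, so no step beyond the usual scatter is expected in this assay in either direction. The expected step runs a number no higher from compound 3 to compound 4 (the limit leaves the size open) and may well end in another limit. For compound 4 the estimate is 26000 nM (expected range 14000 nM to 50000 nM).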

Compound 4, half-maximal effective concentration: > 26000 nM
Compound 4: no number, only a limit; the forecaster's own chance of this, stated with the estimate: 85%; the middle value lies on the limit itself.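

Compound 4 gives > 26000 nM, which is a limit and not a number. For the compounds shown here, no step from compound 1, compound 2 or compound 3 to compound 4 can therefore be read. The compounds shown leave open what exact value each would give, and whether swapping the group at this place changes that value at all.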